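The source may hold more compounds than are shown below. What is called first, only, known or untested is meant among the compounds shown, and "the series" means these compounds.

Measured compounds, with their results in an assay on isolated protein for agonist activity at Bile acid receptor (Homo sapiens), read by AlphaScreen, with a stated time of 30 min; a higher number here means that more compound is needed for the effect, a lower number that less compound is needed:
compound 1 `CCCc1ccccc1-n1nc(C)c2c1NC(=O)[C@H](C)S[C@@H]2c1ccc(Oc2ccccc2)cc1` gives 1100 nM
compound 2 `Cc1nn(-c2ccccc2Cl)c2c1C(c1ccc(Oc3ccccc3)cc1)SC(C)C(=O)N2` gives 2700 nM
compound 3 `Cc1ccccc1-n1nc(C)c2c1NC(=O)[C@H](C)S[C@@H]2c1ccc(-c2ccsc2)cc1` gives 1400 nM

Compound 2 has the highest number of the three in this assay. Its gap to compound 3 is within the scatter, so those two cannot be told apart on these numbers. Its gap to compound 1 is beyond the scatter: compound 1 needs less compound for the effect than compound 2.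

Compound 4 `Cc1nn(-c2ccccc2F)c2c1C(c1ccc(Oc3ccccc3)cc1)SC(C)C(=O)N2` has not yet been measured in this assay. It differs from compound 2 in one place: fluoro in place of chloro on an aromatic carbon. For the measured compounds named here, no measured pair carries this same change, so there is no step to size it from. The expectation is a step no larger than the scatter, with no direction that can be called from what is known. Compound 4 is therefore estimated at 2500 nM, with a range from 1000 nM to 6000 nM. The expected step is a 1.1-fold lower number from compound 2 to compound 4 (0.03 log units; within the scatter), within the scatter.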

Compound 4, half-maximal effective concentration: 3900 nM
Beside the measured number, compound 4's estimate is 1.6-fold (0.19 log units) below it, within the range that was stated.
By their numbers in this assay, from the lowest: compounds 1, 3, 2 and 4 (each within the scatter of the next, the first and the last beyond it).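

In this assay, for the compounds shown here, the exchange of 2-chlorophenyl for 2-fluorophenyl gives a 1.4-fold higher number from compound 2 to compound 4 (0.16 log units; within the scatter), the first step that sizes a change at this place, on an aromatic carbon ortho to a large group. On these numbers compound 2 and compound 4 cannot be told apart, so this one exchange of chloro for fluoro leaves the read-out unresolved. No supporting measurement bears on this result.

From the compounds shown here alone, whether an amine, a methoxy group or a carboxylic acid at this place would give a step beyond the scatter remains open. Going by these compounds, compound 1 and compound 3 carry a propyl and a methyl group on that ring but also differ elsewhere, so the effect of an alkyl group at this place also remains open.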